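Aryl amide at the carbonyl of a catechol thiadiazole series

The compounds below may be only part of what the source reports. "The series", "measured", "known", "first", "only" and "open" are said of these compounds alone.

Of the compounds shown here, three of one series have been measured in a functional assay on HeLa cells (Homo sapiens) for cytotoxicity, read by MTT assay, with a stated time of 72 h; a lower number here means a stronger inhibitor, a higher number a weaker inhibitor. Compound 1 `O=C(Nc1nnc(-c2cccc(O)c2O)s1)C1CCCCC1` gives 91600 nM. Compound 3 `CC(=O)Nc1nnc(-c2cccc(O)c2O)s1` gives 177000 nM. Compound 2 `CC(=O)Nc1nnc(-c2ccc(O)c(O)c2)s1` gives 125000 nM; its gaps to compound 1 and to compound 3 both stay within the scatter, so the three numbers cannot be told apart.

Compound 4 `Cc1ccc(C(=O)Nc2nnc(-c3ccc(O)c(O)c3)s2)cc1` is not yet measured. It differs from compound 2 in one place: 4-methylphenyl in place of methyl on a carbonyl carbon.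

Going by the values given here, the only measured step at the same place is a 1.9-fold higher number from compound 1 to compound 3 (0.29 log units; within the scatter), a swap between a small and a bulky saturated group on the carbonyl carbon, which did not move the number beyond the scatter. Among the compounds with values here, no aromatic group has yet been tried on that carbon, so the step to compound 4 is not covered directly; the nearest evidence points to little change. For compound 4 the number in this assay is therefore expected to lie close to that of compound 2, with a step of a 1.3-fold lower number from compound 2 to compound 4 (0.10 log units; within the scatter) treated as no movement beyond the scatter. The estimate for compound 4 is 100000 nM, within 40000 nM to 250000 nM.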

Compound 4, half-maximal inhibitory concentration: 67100 nM
Compound 4: middle estimate off by 1.5-fold (0.17 log units), on the high side; low and high end bracket the measured number.
By their numbers in this assay, from the lowest: compounds 4, 1, 2 and 3 (each within the scatter of the next, the first and the last beyond it).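

Going by these compounds alone, with 4-methylphenyl in place of methyl on a carbonyl carbon, this assay shows a 1.9-fold lower number from compound 2 to compound 4 (0.27 log units; within the scatter) and so no movement beyond the scatter, even though this is the first aromatic group at this position. The earlier step, a 1.9-fold higher number from compound 1 to compound 3 (0.29 log units; within the scatter), involved only saturated groups; across the two steps, neither a cyclohexyl nor a 4-methylphenyl group separates from methyl at this carbon. No measurement is available here that would account for this flat response.

From the compounds shown here alone, whether an amine or a carboxylic acid on the aromatic ring, or a longer chain on the carbonyl carbon, would move the number beyond the scatter remains open. Cyclohexyl and 4-methylphenyl also remain unread against each other on a single core, as compound 1 and compound 4 differ in more than one place.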